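Replacing the dichlorophenyl-ethenyl arm with a chloro-fluorophenyl ring

This account rests on a few compounds, and the source may have more. Where it says the series, first, only, none or still open, it means among the compounds named here.

Measured so far:
Compound 1, `COC(=O)/C=C/c1cccc(N(Cc2ccc(/C=C/c3c(Cl)cccc3Cl)cc2)C(=O)C(C)C)c1`: 195 nM
Compound 2, `COC(=O)/C=C/c1cccc(N(Cc2ccc(/C=C/c3c(Cl)cccc3Cl)cc2)C(=O)C2CCCCC2)c1`: 150 nM

The two measured compounds share one core and differ only in the group on the carbonyl carbon. In an assay on isolated protein with Bile acid receptor (Homo sapiens) as the target (a higher number here means that more compound is needed for the effect, a lower number that less compound is needed), compound 1 gives 195 nM, and compound 2 gives 150 nM. Compound 1 thus stands at the upper of the two numbers, but the step of a 1.3-fold lower number from compound 1 to compound 2 (0.11 log units; within the scatter) is within the scatter, so the two compounds cannot be told apart on these data.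

Compound 3, `COC(=O)/C=C/c1cccc(N(Cc2ccc(-c3ccc(F)c(Cl)c3)cc2)C(=O)C(C)C)c1`, has not been measured. It differs from compound 1 at another position altogether: 3-chloro-4-fluorophenyl in place of 2-(2,6-dichlorophenyl)ethenyl on an aromatic carbon. Within the data shown here, the only measured step, cyclohexyl in place of isopropyl on the carbonyl carbon, touches a different part of the molecule and therefore says nothing about this change. Among the measured compounds shown here, with no step bearing on it, the direction of the change cannot be read from the data, and the expectation must be wide. Compound 3 is estimated at 400 nM, with a range from 80 nM to 2000 nM. The implied step, a 2.1-fold higher number from compound 1 to compound 3 (0.31 log units; beyond the scatter), is expected to be uncertain in direction.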

Compound 3, half-maximal effective concentration: 129 nM
For compound 3 the middle estimate is 3.1-fold (0.49 log units) above the measured one; low and high end bracket the measured number.
By their numbers in this assay, from the lowest: compounds 3, 2 and 1 (each within the scatter of the next).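

Swapping the arm on the aromatic carbon para to a large group, a part of the molecule that compounds 1 and 2 left unchanged, gives a 1.5-fold lower number from compound 1 to compound 3 (0.18 log units; within the scatter) in this assay. In this pair, 3-chloro-4-fluorophenyl, with 8 heavy atoms and no double bond outside its ring, therefore cannot be told apart from 2-(2,6-dichlorophenyl)ethenyl, with 10 heavy atoms and one such double bond, so this position accepts quite different arms without a readable shift in the number, though the double bond and the halogen pattern change together and their separate contributions cannot be split. No measurement shown offers an explanation for this result.

From the compounds shown here alone, it remains open whether a group that differs from these two only in its halogens or its link, such as plain phenyl or a 2,6-dichlorophenyl ring attached directly, would also stay within the scatter. Also open, going by these compounds, are how a nitrogen-containing ring such as pyridyl would behave at this position and whether cyclohexyl on the carbonyl carbon would pair with 3-chloro-4-fluorophenyl to give a number close to these.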